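The source may report more compounds than this note shows. Statements on the series, on what has been measured and on what is new or still open speak of the compounds shown alone.

Measured compounds:
Compound 1 `COCCNC(=O)c1nc(C(C)(C)NC(=O)OCc2ccccc2)nc(O)c1O` gives 348000 nM in an ADME assay on C8166 cells (Homo sapiens) for cytotoxicity, read by MTT assay, with a stated time of 3 days; on this read-out lower numbers stand for higher toxicity in this test and higher numbers for lower toxicity in this test.
Compound 2 `CC(C)(NC(=O)OCc1ccccc1)c1nc(O)c(O)c(NC(=O)NCc2ccc(F)cc2)n1` gives 81100 nM in this assay.

Of the two numbers, compound 1 holds the higher one, meaning the lower toxicity; compound 2 lies below it by a gap that exceeds the usual scatter of repeated measurements.

Compound 3 `COc1cc(CNC(=O)c2nc(C(C)(C)NC(=O)OCc3ccccc3)nc(O)c2O)cc(OC)c1OC` has not yet been measured in this assay. It differs from compound 1 by 3,4,5-trimethoxyphenyl in place of methoxymethyl on a saturated chain carbon bound to an amide-type nitrogen. Among the compounds with values here, no step between two measured compounds touches this part of the shared core, so the data give no direct guide to the size of the change. The account expects a moderate move toward lower numbers in this assay, a step that may sit near the edge of the scatter rather than far beyond it. Compound 3 is thus expected to give 150000 nM in this assay, within a range from 40000 nM to 400000 nM. The expected step amounts to a 2.3-fold lower number from compound 1 to compound 3 (0.37 log units; beyond the scatter).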

Compound 3, half-maximal cytotoxic concentration: 110000 nM
Compound 3: middle estimate off by 1.4-fold (0.13 log units), on the high side, within the range that was stated.
By their numbers in this assay, from the lowest: compounds 2 and 3 (each within the scatter of the next); then compound 1.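

The position on the saturated chain carbon bound to an amide-type nitrogen is not silent in this assay: 3,4,5-trimethoxyphenyl in place of methoxymethyl gives a 3.2-fold lower number from compound 1 to compound 3 (0.50 log units; beyond the scatter), a modest step toward higher toxicity in this test. Within the data shown here, the earlier compounds offered no step at this place, so this is the first sign that the number responds to a change here, and the step stays modest even though a six-membered aromatic ring enters where no ring stood before. Nothing measured in this account explains the step.

Going by these compounds, it remains open whether the step comes from the aromatic ring itself or from its methoxy groups, which an unsubstituted phenyl at this place would separate. A morpholine or a carboxylic acid on the same chain would show how far the number moves with groups of another kind.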